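This account rests on a few compounds, and the source may have more. Where it says the series, first, only, none or still open, it means among the compounds named here.

Compound 1 `[N-]=[N+]=NCc1cn([C@H]2C[C@H](O)[C@@H](CO)O2)c(=O)[nH]c1=O` gives 124000 nM in an ADME assay on L1210/0 cells (Mus musculus) for cytotoxicity, with a stated time of 48 h; on this read-out higher numbers stand for weaker inhibition and lower numbers for stronger inhibition.
Compound 2 `O=c1[nH]c(=O)n([C@H]2C[C@H](O)[C@@H](CO)O2)cc1C#CCCO` reaches only the limit > 200000 nM in this assay.
Compound 3 `CC(C)(C)C#Cc1cn([C@H]2C[C@H](O)[C@@H](CO)O2)c(=O)[nH]c1=O` likewise reaches only the limit > 200000 nM in this assay.

Compound 3 thus stands at the ceiling of this assay, which is the limit of > 200000 nM in this assay, at which 2 of the 3 values shown sit. Against compound 1 the step reads an at least 1.6-fold higher number from compound 1 to compound 3 (0.20 log units; that floor lies within the scatter), and between the two limit values the step that the two limits leave unreadable from compound 2 to compound 3 cannot be sized at all. Compound 4 `CCCCCC#Cc1cn([C@H]2C[C@H](O)[C@@H](CO)O2)c(=O)[nH]c1=O` differs from compound 3 by pentyl in place of tert-butyl on a triple-bonded carbon. Within the data shown here, only one measured step concerns a change on the triple-bonded carbon, and it gives no guidance, since a step that the two limits leave unreadable from compound 2 to compound 3 has no readable size. Among the measured compounds shown here, the one comparison with a number behind it, an at least 1.6-fold higher number from compound 1 to compound 3 (0.20 log units; that floor lies within the scatter), shows only a floor that lies within the scatter. Compound 4 is therefore expected to come out at the same limit, and the estimated step of a number no higher from compound 3 to compound 4 (the limit leaves the size open) amounts to no change beyond the scatter. The estimate for compound 4 is 200000 nM, lying between 100000 nM and 400000 nM.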

Compound 4, half-maximal inhibitory concentration: > 200000 nM
Compound 4 ended at the assay's limit; the forecaster's own chance of this, stated with the estimate: 70%; the middle value lies on the limit itself.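

Compound 4 is a third compound with a chain joined through the triple-bonded carbon that sits at the ceiling of this assay, so pentyl in place of tert-butyl brings no readable gain over the branched group: the limit of > 200000 nM in this assay, at which 3 of the 4 values shown sit.

Among these compounds, the only step here with any reading is an at least 1.6-fold higher number from compound 1 to compound 4 (0.20 log units; that floor lies within the scatter), so hept-1-yn-1-yl in place of azidomethyl shows no difference beyond the scatter. The steps among compound 2, compound 3 and compound 4 cannot be read, as both ends of each are limits.

On these data alone, how far these three compounds lie past the limit stays open. As far as these compounds go, whether an amine, a carboxylic acid or a longer chain in place of pentyl would give a value in this assay rather than a limit also stays open.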